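Methyl for phenyl on the core of compound 2

This account rests on a few compounds, and the source may have more. Where it says the series, first, only, none or still open, it means among the compounds named here.

Compound 2 `CC(C)c1nc2c(c(-c3ccccc3)nn2C)c(-c2ccc(F)cc2)c1/C=C/[C@@H](O)C[C@@H](O)CC(=O)O` stands highest of the three numbers in an in vivo functional assay on the whole organism for inhibition of 3-hydroxy-3-methylglutaryl-coenzyme A reductase (Rattus norvegicus), at a dose of 0.2 mg/kg by the oral route (a higher number here means a stronger effect of the compound at the dose given, a lower number a weaker effect), where compound 2 gives 37%. Going by the values given here, compound 1 `COc1ccc(-n2nc(C)c3c(-c4ccc(F)cc4)c(/C=C/[C@@H](O)C[C@@H](O)CC(=O)O)c(C(C)C)nc32)cc1` gives -27.5% in this assay, and compound 3 `Cn1nc(-c2ccccc2)c2c(-c3ccc(F)cc3)c(/C=C/[C@@H](O)C[C@@H](O)CC(=O)O)c(C3CC3)nc21` gives -54.4%; the one step between neighbours that differ in one place is a number 91.4 percentage points lower from compound 2 to compound 3 (beyond the scatter).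

Compound 4 `Cc1nn(C)c2nc(C(C)C)c(/C=C/[C@@H](O)C[C@@H](O)CC(=O)O)c(-c3ccc(F)cc3)c12` differs from compound 2 in one place: methyl in place of phenyl on an aromatic carbon. Among the compounds with values here, no measured step shows this exact change. The step from compound 2 to compound 3 concerns another group and does not bear on it, although it shows that one change on this core can move the read-out far beyond the scatter. Compound 1 carries a methyl at the same place as compound 4, yet it also differs from compound 2 at the ring nitrogen. The value of compound 1, -27.5%, can therefore only hint that the methyl-bearing compounds may sit lower than compound 2.

Compound 4 is therefore expected to come in below compound 2, with a step of about a number 32 percentage points lower from compound 2 to compound 4 (beyond the scatter). The estimate for compound 4 in this assay is 5%, with a range from -40% to 40% that reflects the absence of a direct comparison.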

Compound 4, a percentage reported as inhibition, in the whole organism at one dose (the size of the read-out at that dose, not a potency): 41.1%
Compound 4: middle estimate off by 36.1 percentage points, on the low side, outside the stated range (above it).
By their numbers in this assay, from the lowest: compound 3; then compound 1; then compounds 2 and 4 (each within the scatter of the next).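

In this assay, the phenyl on the aromatic carbon of the five-membered aromatic ring gives way to methyl with a number 4.1 percentage points higher from compound 2 to compound 4 (within the scatter), so on this core neither the six carbon atoms of the phenyl nor its aromatic ring is needed to hold the read-out at this dose. The large change appears at the other place instead: methyl in place of 4-methoxyphenyl on an aromatic nitrogen gives a number 68.6 percentage points higher from compound 1 to compound 4 (beyond the scatter), which shows that the low value of compound 1 goes with its nitrogen substituent and not with the methyl it shares with compound 4. Nothing measured here explains either step.

From the compounds shown here alone, whether an amine, a carboxylic acid or a longer chain on the same aromatic carbon would also leave the read-out within the scatter remains open. Going by these compounds, it is also open whether cyclopropyl in place of isopropyl would cost compound 4 as much as it costs on the phenyl-bearing core, where the change gives a number 91.4 percentage points lower from compound 2 to compound 3 (beyond the scatter), and a single-dose read-out cannot show whether compound 2 and compound 4 match in potency.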